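A swapped side group on compound 2

The compounds below may be only part of what the source reports. "The series", "measured", "known", "first", "only" and "open" are said of these compounds alone.

compound 1 `C=CC(=O)Nc1cc(Nc2ncc(Cl)c(Nc3ccccc3S(=O)(=O)C(C)C)n2)c(OC(C)C)cc1N1CCN(CC)CC1` gives 300 nM
compound 2 `C=CC(=O)Nc1cc(Nc2ncc(Cl)c(Nc3ccc(F)c(Cl)c3)n2)c(OC)cc1N1CCN(C)CC1` gives 100 nM

In a functional assay on NCI-H1975 cells (Homo sapiens) for inhibition, read by CellTiter-Glo, with a stated time of 72 h (on this read-out lower numbers stand for stronger inhibition of growth and higher numbers for weaker inhibition of growth), compound 2 holds the lowest of the two numbers (100 nM), and the gap to compound 1 (300 nM) lies beyond the scatter. These two compounds differ in more than one place, so their gap cannot be tied to any single group.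

Compound 3 `C=CC(=O)Nc1cc(Nc2ncc(Cl)c(N(C)c3cccc(C(F)(F)F)c3)n2)c(OC)cc1N1CCN(C)CC1` has not yet been measured. Compared with compound 2, it carries methyl(3-(trifluoromethyl)phenyl)amino in place of (3-chloro-4-fluorophenyl)amino on an aromatic carbon. Within the data shown here, no measured pair shows this change alone, so the expectation is loose. Compound 2 already has the lower number, and a move toward weaker inhibition of growth in this assay is expected, an estimated step (a 3.0-fold higher number from compound 2 to compound 3 (0.48 log units; beyond the scatter)) beyond the scatter. For compound 3 the estimated value is 300 nM (expected range 80 nM to 1200 nM).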

Compound 3, concentration for 50% growth inhibition: 1800 nM
Compound 3: middle estimate off by 6.0-fold (0.78 log units), on the low side; the whole stated range lies below it.
By their numbers in this assay, from the lowest: compound 2; then compound 1; then compound 3.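

In this assay, among these compounds, replacing (3-chloro-4-fluorophenyl)amino with methyl(3-(trifluoromethyl)phenyl)amino gives an 18-fold higher number from compound 2 to compound 3 (1.26 log units; beyond the scatter), the first comparison here that changes only one place, and it shows that growth inhibition depends strongly on the group at this position on the shared core. This single swap bundles several differences: the entering group has no hydrogen-bond donor while the leaving group has one, it has more heavy atoms, and its ring carries trifluoromethyl rather than chloro and fluoro. No measurement here ties the step to any one of these differences or explains it.

The compounds shown leave open whether the methyl on the nitrogen or the ring substituents matter more. Comparing (3-(trifluoromethyl)phenyl)amino or methyl(3-chloro-4-fluorophenyl)amino at this position would separate the two.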